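Tolerated concentrations across the amide series

The source may hold more compounds than are shown below. What is called first, only, known or untested is meant among the compounds shown, and "the series" means these compounds.

Compound 1 `COc1ccc2nc(C)cc(OCC(=O)Nc3ccccc3)c2c1` is the reference point. In an ADME assay on HepG2 cells (Homo sapiens) for cytotoxicity, read by trypan blue exclusion, with a stated time of 48 h, in the presence of a further agent that is not named here (a lower number here means that less compound is tolerated, a higher number that more compound is tolerated), compound 1 gives only a limit of the assay, > 155000 nM, and not a number. Compound 2 `COc1ccc2nc(C)cc(OCC(=O)Nc3cccc(Br)c3)c2c1` also reaches only a limit in this assay, > 125000 nM. Compound 3 `COc1ccc2nc(C)cc(OCC(=O)Nc3ccccc3Cl)c2c1` likewise stops at a limit in this assay, > 140000 nM. Hence the steps a step that the two limits leave unreadable from compound 1 to compound 2, a step that the two limits leave unreadable from compound 1 to compound 3 and a step that the two limits leave unreadable from compound 2 to compound 3 cannot be sized: every one of the three values sits at its own limit, as shown by the limit of > 125000 nM in this assay, at which 1 of the 3 values shown sits, the limit of > 140000 nM in this assay, at which 1 of the 3 values shown sits, and (the limit of > 155000 nM in this assay, at which 1 of the 3 values shown sits).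

Compound 4 `COCCNC(=O)COc1cc(C)nc2ccc(OC)cc12` differs from compound 1 by 2-methoxyethyl in place of phenyl on an amide-type nitrogen. Going by the values given here, none of the measured steps touches this kind of change; each swaps a substituent on the aromatic ring or exchanges one substituted phenyl for another, and each is unreadable. Among the compounds with values here, the only reading the three values support is that none of the amides tested so far reached a half-maximal cytotoxic concentration within the range examined, so no direction beyond the scatter is expected for an at least 1.0-fold lower number from compound 1 to compound 4 (0.01 log units; that floor lies within the scatter). Compound 4 is therefore expected to give 150000 nM in this assay, within 60000 nM to 400000 nM, most probably again reported as a limit.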

Compound 4, half-maximal cytotoxic concentration: > 164000 nM
Compound 4 ended at the assay's limit; the forecaster's own chance of this, stated with the estimate: 85%; middle value at least 1.0-fold (0.03 log units) away from the limit.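

In this assay compound 4 gives only a limit of the assay, > 164000 nM; none of its steps from compound 1, compound 2 or compound 3 can be read. The compounds shown leave open at what concentration any of these four amides reaches half-maximal cytotoxicity.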